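Aryl and Alkyl Groups on an Acylguanidine Series

This account rests on a few compounds, and the source may have more. Where it says the series, first, only, none or still open, it means among the compounds named here.

Measured so far:
compound 1 `CCCNC(=O)/N=C(\N)Nc1cccc(-c2csc(N)n2)c1` – 5250 nM
compound 2 `Cc1nc(N)sc1CCCN/C(N)=N/C(=O)NC1CCCCC1` – 170 nM
compound 3 `Cc1nc(N)sc1CCCN/C(N)=N/C(=O)NC(c1ccccc1)c1ccccc1` – 43.7 nM

Of the compounds shown here, three have been tested in an assay on membranes from Sf9 cells for displacement of a labelled ligand from histamine H2 receptor (Homo sapiens), read by scintillation counting, with a stated time of 60 min; on this read-out lower numbers stand for stronger inhibition and higher numbers for weaker inhibition. Compound 1 `CCCNC(=O)/N=C(\N)Nc1cccc(-c2csc(N)n2)c1` gives 5250 nM, compound 2 `Cc1nc(N)sc1CCCN/C(N)=N/C(=O)NC1CCCCC1` gives 170 nM, and compound 3 `Cc1nc(N)sc1CCCN/C(N)=N/C(=O)NC(c1ccccc1)c1ccccc1` gives 43.7 nM. Compound 2 holds the middle place of the three: its number lies well below that of compound 1 and well above that of compound 3, both gaps lying beyond the usual scatter.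

Compound 4 `Cc1nc(N)sc1CCCN/C(N)=N/C(=O)N[C@H](C)c1ccccc1` has not yet been measured. It differs from compound 2 in one place: 1-phenylethyl in place of cyclohexyl on an amide-type nitrogen. The group that enters lies, in its make-up, somewhere between the cyclohexyl of compound 2 and the two phenyl rings of compound 3, so the step is expected to be small to moderate and toward a lower number.

For compound 4 the expected result in this assay is 100 nM, with a range from 30 nM to 400 nM. This estimate means an expected step of a 1.7-fold lower number from compound 2 to compound 4 (0.23 log units; within the scatter).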

Compound 4, inhibition constant: 17.8 nM
Estimate against measurement, compound 4: 5.6-fold (0.75 log units) above, outside the stated range (below it).
By their numbers in this assay, from the lowest: compound 4; then compound 3; then compound 2; then compound 1.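

Swapping cyclohexyl for 1-phenylethyl on the amide-type nitrogen gives a 9.6-fold lower number from compound 2 to compound 4 (0.98 log units; beyond the scatter) on this read-out, so the group at this position has a clear effect on the result. Going by these compounds alone, no two compounds measured earlier differed in one place only, which makes this the first direct reading of the position: here, a group with an aromatic ring and a defined stereocentre goes with stronger inhibition than the non-aromatic ring of compound 2. Within the data shown here, nothing measured so far explains this gain.

A benzyl group on this nitrogen, or the mirror-image form of 1-phenylethyl, would help show whether the aromatic ring or the stereocentre accounts for the step. As far as these compounds go, how an amine or a carboxylic acid on the phenyl ring would fare also remains open.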